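Phenyl Gives Way to Chloro on a Shared Core

The source may report more compounds than this note shows. Statements on the series, on what has been measured and on what is new or still open speak of the compounds shown alone.

Compound 1 `COc1ccc(C(=O)/C=C/c2ccc(-c3ccccc3)cc2)c2c1C=CC(C)(C)O2` is the starting point of this account. In a functional assay on SK-OV-3 cells (Homo sapiens) for antiproliferative activity, read by MTT assay, with a stated time of 24 h (on this read-out lower numbers stand for stronger inhibition and higher numbers for weaker inhibition), compound 1 gives > 10000 nM, which is a limit of the assay and not a number. Two companions share its core and differ from it at the outer aromatic ring. Compound 2 `COc1ccc(C(=O)/C=C/c2ccc(N(c3ccccc3)c3ccccc3)cc2)c2c1C=CC(C)(C)O2` is one of them; in this assay compound 2 likewise gives > 10000 nM, a limit rather than a measured value. Compound 3 `COc1ccc(C(=O)/C=C/c2cccc3ccccc23)c2c1C=CC(C)(C)O2` is the other; in this assay compound 3 also returns > 10000 nM, again a limit. Every value shown so far therefore sits at the same ceiling, as the limit of > 10000 nM in this assay, at which 3 of the 3 values shown sit, records, and none of the three compounds can be ranked against another on these numbers.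

Compound 4 `COc1ccc(C(=O)/C=C/c2ccc(Cl)cc2)c2c1C=CC(C)(C)O2` differs from compound 1 in one place: chloro in place of phenyl on an aromatic carbon. Among the measured compounds no step has a measurable size, since all three stand at the limit. The step that the limit leaves unreadable from compound 1 to compound 4 is expected to be small, in no clear direction, and not beyond the scatter. Compound 4 is expected to give about 15000 nM, within a range from 3000 nM to 60000 nM.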

Compound 4, half-maximal inhibitory concentration: > 10000 nM
Compound 4: only a limit was reported; the forecaster's own chance of this, stated with the estimate: 70%; the middle value does not contradict the limit.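

In this assay compound 4 gives > 10000 nM, which is a limit and not a number. The step from compound 1 to compound 4 therefore cannot be read, because both compounds stand at the same ceiling: the limit of > 10000 nM in this assay, at which 4 of the 4 values shown sit.

The compounds shown leave open whether any group on the outer aromatic ring of the shared core gives a measurable value.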